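The source may report more compounds than this note shows. Statements on the series, on what has been measured and on what is new or still open speak of the compounds shown alone.

In an ADME assay on L132 cells (Homo sapiens) for cytotoxicity, read by MTT assay, with a stated time of 48 h (a lower number here means a stronger inhibitor, a higher number a weaker inhibitor), compound 1 `C/C(=C\CC/C(C)=C/CC[C@@H]1[C@@]2(C)CCC(=O)C(C)(C)[C@H]2CC[C@@]1(C)O)CC/C=C(\C)C(=O)OCc1cn(-c2cccc(Cl)c2)nn1` gives 94200 nM. Compound 2 `C/C(=C\CC/C(C)=C/CC[C@@H]1[C@@]2(C)CCC(=O)C(C)(C)[C@H]2CC[C@@]1(C)O)CC/C=C(\C)C(=O)OCc1cn(-c2ccc(Cl)cc2)nn1` stands at > 150000 nM, which is a limit of the assay and not a number. Compound 3 `C/C(=C\CC/C(C)=C/CC[C@@H]1[C@@]2(C)CCC(=O)C(C)(C)[C@H]2CC[C@@]1(C)O)CC/C=C(\C)C(=O)OCc1cn(-c2ccc(C)cc2)nn1` differs from compound 2 in one substituent: methyl in place of chloro on an aromatic carbon. In words, this is methyl in place of chloro on an aromatic carbon, para to a large group, so that 4-chlorophenyl becomes 4-methylphenyl.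

One measured step lies close to this change: an at least 1.5-fold higher number from compound 1 to compound 2 (0.20 log units; that floor lies within the scatter). That step relocates the chloro rather than replacing it, so it bears on the present change only indirectly. Among the measured compounds shown here, no measured step covers a swap of chloro for methyl. On this basis, no step beyond the scatter is expected in this assay, and no direction can be favoured. For the measured compounds named here, the only actual number nearby is that of compound 1, at 94200 nM, which sets the lower part of the expected range. The expected step is an at least 1.1-fold lower number from compound 2 to compound 3 (0.06 log units; that floor lies within the scatter). For compound 3 the estimated value is 130000 nM, with an expected range from 70000 nM to 240000 nM.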

Compound 3, half-maximal inhibitory concentration: > 150000 nM
Compound 3 was reported as a limit; the forecaster's own chance of this, stated with the estimate: 45%; at least 1.1-fold (0.06 log units) between middle value and limit.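

In this assay compound 3 gives > 150000 nM, which is a limit of the assay and not a number. The swap of chloro for methyl on the aromatic carbon para to a large group cannot be read, because compound 2 and compound 3 both sit at the same limit: the limit of > 150000 nM in this assay, at which 2 of the 3 values shown sit. What is new is that a second group in this place, methyl as well as chloro, leaves the result at that limit, and the comparison with the 3-chlorophenyl compound gives an at least 1.5-fold higher number from compound 1 to compound 3 (0.20 log units; that floor lies within the scatter), a floor that lies within the scatter, so neither 4-substituted compound is separated from compound 1 by a readable margin.

Still open, on these data alone, is whether any group on this aromatic carbon brings the result back into the measurable range, for example an amine or a carboxylic acid in place of the methyl. Also open, as far as these compounds go, is whether a methyl on the other ring position, as in a 3-methylphenyl compound, would give a number close to that of compound 1 or would again give a limit.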